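The compounds below may be only part of what the source reports. "The series", "measured", "known", "first", "only" and "open" are said of these compounds alone.

Four compounds share one core. Compound 1 `Cc1cn2c(-c3cn[nH]c3)cnc2c(Nc2cc(Cn3cccn3)ns2)n1` is recorded in an ADME assay on the whole organism for pharmacokinetics, with Rattus norvegicus as the target, with a stated time of 6 h, at a dose of 10 mg/kg by the oral route (a higher number here means more compound in the circulation at the dose given, a lower number less compound in the circulation), as "not determined" (no result reported). Compound 2 `Cc1cn2c(-c3cn[nH]c3)cnc2c(Nc2cc(Cc3ncccc3C)ns2)n1` gives 644 ng.h/mL in this assay, and compound 3 `Cc1cn2c(-c3cn[nH]c3)cnc2c(Nc2cc(Cc3ncccc3F)ns2)n1` gives 569 ng.h/mL. Among the compounds with values here, the step of a 1.1-fold lower number from compound 2 to compound 3 (0.05 log units; within the scatter) lies within the scatter, so compound 3 sits beside the only other number at a distance that means nothing. Compound 4 `COc1cccc(Cc2cc(Nc3nc(C)cn4c(-c5cn[nH]c5)cnc34)sn2)n1` differs from compound 3 by 6-methoxypyridin-2-yl in place of 3-fluoropyridin-2-yl on a saturated chain carbon bound to an aromatic carbon. Within the data shown here, the single measured step at this position, the one just described, changed the number little; the present exchange is larger in what leaves and enters, yet no measured comparison here points in either direction. Compound 4 is therefore expected to show a step of a 1.0-fold higher number from compound 3 to compound 4 (0.00 log units; within the scatter), with an estimated 570 ng.h/mL and a range of 200 ng.h/mL to 1600 ng.h/mL.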

Compound 4, area under the concentration-time curve: 2300 ng.h/mL
Compound 4: the middle estimate sits 4.0-fold (0.61 log units) below what was measured, and the stated range ends below it.
By their numbers in this assay, from the lowest: compounds 3 and 2 (each within the scatter of the next); then compound 4.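

The group on the saturated chain carbon bound to an aromatic carbon can move the number in this assay beyond the scatter: 6-methoxypyridin-2-yl gives a clear step in place of 3-fluoropyridin-2-yl (a 4.0-fold higher number from compound 3 to compound 4 (0.61 log units; beyond the scatter)) and in place of 3-methylpyridin-2-yl (a 3.6-fold higher number from compound 2 to compound 4 (0.55 log units; beyond the scatter)). On these data alone, the earlier exchange of fluoro for methyl had stayed within the scatter and gave no sign of this. (Nothing measured here accounts for the size of these steps) It remains open whether the methoxy group itself carries the higher number, and whether an ethoxy group or an amine in its place would do the same.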